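Working notes: pyridin-2-yl in place of 1H-imidazol-1-yl

The compounds below may be only part of what the source reports. "The series", "measured", "known", "first", "only" and "open" are said of these compounds alone.

Measured in a physicochemical assay for solubility, read by chemiluminescence; a higher number here means a more soluble compound, a lower number a less soluble compound
- compound 1 `CN1CCC(C(=O)N(CC(=O)Nc2cc(F)cc(F)c2)C2CCCCC2)CC1` gives 140 ug/mL
- compound 2 `O=C(CN(C(=O)c1ccc(-n2ccnc2)cc1)C1CCCCC1)Nc1cc(F)cc(F)c1` gives 32 ug/mL

Compound 2 holds the lower of the two numbers, and its nearest neighbour, compound 1 at 140 ug/mL, lies beyond the scatter above it. The next compound to be read is compound 3 `O=C(CN(C(=O)c1ccc(-c2ccccn2)cc1)C1CCCCC1)Nc1cc(F)cc(F)c1`, which has pyridin-2-yl in place of 1H-imidazol-1-yl on an aromatic carbon, para to a large group pyridin-2-yl in place of 1H-imidazol-1-yl on an aromatic carbon with the rest of compound 2 unchanged. Among the compounds with values here, no measured pair covers this change. The only anchor for the expectation is compound 2 at 32 ug/mL in this series. A downward move in this assay is expected, of modest size and probably just beyond the scatter, with the estimated change a 2.3-fold lower number from compound 2 to compound 3 (0.36 log units; beyond the scatter) on this read-out. Compound 3 is estimated at 14 ug/mL with an expected range of 4 ug/mL to 40 ug/mL for the coming reading.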

Compound 3, solubility: 6 ug/mL
Beside the measured number, compound 3's estimate is 2.3-fold (0.37 log units) above it, and the stated range covers the measured number.
By their numbers in this assay, from the lowest: compound 3; then compound 2; then compound 1.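

In this assay the aromatic carbon para to a large group is shown to respond to the ring it carries: pyridin-2-yl in place of 1H-imidazol-1-yl gives the step (a 5.3-fold lower number from compound 2 to compound 3 (0.73 log units; beyond the scatter)), which lies beyond the scatter. This is the only step shown that changes a single place, and so the only direct reading of this position. The change swaps a five-membered aromatic ring with 2 hetero atoms for a six-membered aromatic ring with 1 hetero atom, and no data shown here account for the step.

On these data alone, a single step cannot separate ring size from the count of ring hetero atoms, so which of the two tracks with the read-out remains open. Also open, as far as these compounds go, is how this position would read with a pyridin-3-yl ring, or with a non-aromatic group such as an amine or a carboxylic acid.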